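The compounds below may be only part of what the source reports. "The series", "measured", "known", "first", "only" and "open" are said of these compounds alone.

Measured compounds:
- compound 1 `CC(C)Oc1cncc(C2=CC3CNCC(C2)C3)c1`: 0.26 nM
- compound 2 `COc1cccc(Oc2cncc(C3=CC4CNCC(C3)C4)c2)c1`: 0.9 nM
- compound 3 `C1=C(c2cccnc2)C[C@H]2CNC[C@@H]1C2`: 0.2 nM

In an in vitro assay on SH-EP1 cells for displacement of a labelled ligand from Neuronal acetylcholine receptor; alpha4/beta2 (Homo sapiens) (on this read-out lower numbers stand for stronger inhibition and higher numbers for weaker inhibition), compound 2 stands at the highest number of the three; compound 1 lies nearest with a lower number and compound 3 furthest, and both of those gaps are beyond the scatter. The unmeasured compound 4 `C1=C(c2cncc(OCc3ccccc3)c2)CC2CNCC1C2` is reached from compound 2 by a single change: benzyl in place of 3-methoxyphenyl on an oxygen on an aromatic ring.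

Among the measured compounds shown here, only one measured step touches the same oxygen on the aromatic ring: a 3.5-fold higher number from compound 1 to compound 2 (0.54 log units; beyond the scatter), where 3-methoxyphenyl took the place of isopropyl and the number rose by a modest but real amount. For the measured compounds named here, no measured step exchanges one aromatic-bearing group for another on that oxygen, so the benzyl case has no direct precedent; the available steps only show that groups of different kind on this oxygen move the number within a modest span, and that compound 1 and compound 3, which lack the 3-methoxyphenyl, sit at lower numbers.

On that basis compound 4 is expected to stay in the same region as compound 2, with the step of a 1.1-fold higher number from compound 2 to compound 4 (0.05 log units; within the scatter) estimated to be no larger than the scatter, and the value estimated at 1 nM within 0.3 nM to 4 nM.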

Compound 4, inhibition constant: 0.7 nM
For compound 4 the middle estimate is 1.4-fold (0.15 log units) above the measured one; measured number inside the range.
By their numbers in this assay, from the lowest: compounds 3 and 1 (each within the scatter of the next); then compounds 4 and 2 (each within the scatter of the next).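

On the oxygen on an aromatic ring, in this assay, benzyl in place of 3-methoxyphenyl gives a difference that stays inside the scatter (a 1.3-fold lower number from compound 2 to compound 4 (0.11 log units; within the scatter)). Among the compounds shown here, this is the first exchange of one group carrying a six-membered aromatic ring of carbon only for another, and it also shows that losing the hydrogen-bond acceptor counted on 3-methoxyphenyl produces no step beyond the scatter here. Against isopropyl, benzyl now gives a second modest rise (a 2.7-fold higher number from compound 1 to compound 4 (0.43 log units; beyond the scatter)) in the same direction as the earlier one (a 3.5-fold higher number from compound 1 to compound 2 (0.54 log units; beyond the scatter)), so among these three compounds the rise from isopropyl appears with either ring-bearing group, and no information is available on what lies behind this.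

Still open, on these data alone, is whether a small group on this oxygen, such as methyl, or a longer alkyl chain would stay near isopropyl or near the ring-bearing groups. Also open, as far as these compounds go, is how an amine or a carboxylic acid on the benzyl ring would move the number in this assay.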